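A few compounds are considered here, and "the series" means these few. Any claim that something is new, unique, unknown or untested is made for them only; others in the source may bear on it.

Measured compounds:
- compound 1 `CN(CC[C@H](N)C(=O)O)C[C@H]1O[C@@H](n2cnc3c(N)ncnc32)[C@H](O)[C@@H]1O`: 30.3%
- compound 3 `Nc1ncnc2c1ncn2[C@@H]1O[C@H](CN(CC[C@H](N)C(=O)O)CC2CC2)[C@@H](O)[C@H]1O`: 27.5%
- compound 2 `CCCN(CC[C@H](N)C(=O)O)C[C@H]1O[C@@H](n2cnc3c(N)ncnc32)[C@H](O)[C@@H]1O`: no result reported

The series shares one core; the compounds differ in the group on a saturated chain carbon bound to an amine nitrogen. In an assay for inhibition of tRNA (cytosine(38)-C(5))-methyltransferase (Homo sapiens), with a stated time of 5 min, tested at 100 uM (on this read-out lower numbers stand for less inhibition and higher numbers for more inhibition at the one concentration tested (going by the name of the read-out)), compound 1 gives 30.3%, and compound 3 gives 27.5%. The one step with both ends measured, a number 2.8 percentage points lower from compound 1 to compound 3 (within the scatter), is within the scatter, so on the numbers shown compound 3 sits at the lower of the two values without standing apart from compound 1. Compound 2 carries no number and gives no direction.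

Compound 4 `Nc1ncnc2c1ncn2[C@@H]1O[C@H](CN(CC[C@H](N)C(=O)O)CC2CCC2)[C@@H](O)[C@H]1O` is the next step out from compound 3: cyclobutyl in place of cyclopropyl on a saturated chain carbon bound to an amine nitrogen. Going by the values given here, the only step that bears on it is a number 2.8 percentage points lower from compound 1 to compound 3 (within the scatter), in which a ring of carbon only was added at the same place and the read-out did not move beyond the scatter. Growing that ring by one carbon is a smaller change than adding it, so no step beyond the scatter is expected in this assay in either direction. Compound 4 is therefore estimated at 28%, with a range from 15% to 42%, which means an expected step of a number 0.5 percentage points higher from compound 3 to compound 4 (within the scatter).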

Compound 4, a percentage reported as inhibition, at one concentration (the size of the read-out at that concentration, not a potency): 32%
The estimate for compound 4 lay 4 percentage points below the measured number, within the range that was stated.
By their numbers in this assay, from the lowest: compounds 3, 1 and 4 (each within the scatter of the next).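

In this assay, the change from cyclopropyl to cyclobutyl on a saturated chain carbon bound to an amine nitrogen gives a number 4.5 percentage points higher from compound 3 to compound 4 (within the scatter) and so adds a second ring size to the picture, with the four-membered ring of carbon only reading like the three-membered one. The comparison with the hydrogen of the shared core gives a number 1.7 percentage points higher from compound 1 to compound 4 (within the scatter), so both carbon rings now stay within the scatter of compound 1 and the three numbers cannot be put in order. At this one concentration, neither the addition of a carbon ring at this place nor the growth of that ring by one carbon separates these compounds, and no supporting measurement bears on this result.

Steps involving compound 2 cannot be read, so the effect of an open chain at this place remains unknown. On these data alone, whether a larger ring such as cyclohexyl, an aromatic ring such as phenyl, or a group carrying an amine or a carboxylic acid would move the read-out beyond the scatter also remains open.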